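Swapping Methyl for Methylsulfanyl on Compound 1

This account rests on a few compounds, and the source may have more. Where it says the series, first, only, none or still open, it means among the compounds named here.

Compound 1 `COc1cc(-n2ncnc2-c2ccc(C)cc2)cc(OC)c1OC` was tested in a functional assay on K562 cells (Homo sapiens) for antiproliferative activity, read by MTT assay, with a stated time of 72 h; on this read-out lower numbers stand for stronger inhibition and higher numbers for weaker inhibition. In this assay compound 1 gives > 10000 nM, which is a limit of the assay rather than a number. Two related compounds were measured alongside it. Compound 2 `COc1cc(-c2ncnn2-c2cccc(N)c2)cc(OC)c1OC` also gives a limit in this assay, > 10000 nM. Compound 3 `COc1ccc(-n2ncnc2-c2cc(OC)c(OC)c(OC)c2)cc1` gives 3600 nM in this assay. Going by the values given here, the only measured step, an at least 2.7-fold lower number from compound 2 to compound 3 (0.44 log units; beyond the scatter), concerns a group on an aromatic nitrogen and does not touch the position changed here.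

Compound 4 `COc1cc(-n2ncnc2-c2ccc(SC)cc2)cc(OC)c1OC` is the next compound to be measured. It differs from compound 1 in one place: methylsulfanyl in place of methyl on an aromatic carbon. The change sits on an aromatic carbon of a six-membered aromatic ring of carbon only, para to a large group.

Among the compounds with values here, no measured step bears on this exchange, so there is no basis for expecting a step of any particular size in this assay. What is known is the position of compound 1, which sits at the limit described by the limit of > 10000 nM in this assay, at which 2 of the 3 values shown sit. The step from compound 1 to compound 4 is therefore expected to be small, an at least 1.1-fold lower number from compound 1 to compound 4 (0.04 log units; that floor lies within the scatter), and to leave compound 4 weak. Compound 4 is estimated at 9000 nM in this assay, within a range from 2500 nM to 30000 nM.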

Compound 4, half-maximal inhibitory concentration: 340 nM
The estimate for compound 4 lay 26-fold (1.42 log units) above the measured number; measured number below the stated range.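

Methylsulfanyl in place of methyl gives an at least 29-fold lower number from compound 1 to compound 4 (1.46 log units; beyond the scatter), so in this assay the group on this aromatic carbon, para to a large group, has a strong bearing on the read-out. Going by these compounds alone, the earlier compounds could not show this, since their only measured step concerns a group on an aromatic nitrogen, and this is the first measured change at this position. The printed step is a floor and not an exact size, since only a limit is available for compound 1, so the real gap could be larger than the one stated: the limit of > 10000 nM in this assay, at which 2 of the 4 values shown sit.

With only methyl and methylsulfanyl shown at this position, the compounds cannot tell whether the sulfur itself matters or whether other groups placed here would lower the number just as far. A chlorine atom, an amine or a longer chain such as ethylsulfanyl at the same place would help separate these readings, and would show how much room this position leaves around compound 4, which gives 340 nM.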